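Nitro substitution carried onto the piperidine analogue

This account rests on a few compounds, and the source may have more. Where it says the series, first, only, none or still open, it means among the compounds named here.

Compound 3 `COc1cc2c(Oc3ccc(NC(=O)c4nn(-c5ccccc5)c(=O)c5ccccc45)cc3F)ccnc2cc1OCCCN1CCCCC1` gives 590 nM in a functional assay on MKN-45 cells (Homo sapiens) for cytotoxicity, read by MTT assay, with a stated time of 72 h; a lower number here means a stronger inhibitor, a higher number a weaker inhibitor. Compound 1 `COc1cc2c(Oc3ccc(NC(=O)c4nn(-c5ccccc5)c(=O)c5ccccc45)cc3F)ccnc2cc1OCCCN1CCN(C)CC1` gives 620 nM, and the two values lie within the scatter of each other, whereas compound 2 `COc1cc2c(Oc3ccc(NC(=O)c4nn(-c5ccc([N+](=O)[O-])cc5)c(=O)c5ccccc45)cc3F)ccnc2cc1OCCCN1CCN(C)CC1` gives 1320 nM, beyond the scatter from compound 3. Compound 4 `COc1cc2c(Oc3ccc(NC(=O)c4nn(-c5ccc([N+](=O)[O-])cc5)c(=O)c5ccccc45)cc3F)ccnc2cc1OCCCN1CCCCC1` differs from compound 3 by nitro in place of hydrogen on an aromatic carbon. The same change has been followed once before, in the step of a 2.1-fold higher number from compound 1 to compound 2 (0.33 log units; beyond the scatter), while the exchange of the amine at the chain end a 1.1-fold lower number from compound 1 to compound 3 (0.02 log units; within the scatter) left the number essentially unchanged. A step of similar size toward a weaker inhibitor is therefore expected, namely a 2.1-fold higher number from compound 3 to compound 4 (0.33 log units; beyond the scatter). On that basis compound 4 is estimated at 1250 nM, with a range from 700 nM to 2300 nM.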

Compound 4, half-maximal inhibitory concentration: 1140 nM
The estimate for compound 4 lay 1.1-fold (0.04 log units) above the measured number; the measured number falls inside the stated range.
By their numbers in this assay, from the lowest: compounds 3, 1, 4 and 2 (each within the scatter of the next, the first and the last beyond it).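

On the piperidine analogue, the exchange of phenyl for 4-nitrophenyl gives a 1.9-fold higher number from compound 3 to compound 4 (0.29 log units; within the scatter), a second reading of this change that stays within the scatter. The two readings agree: the same change on two cores in this assay, a 2.1-fold higher number (0.33 log units; beyond the scatter) from compound 1 to compound 2 and a 1.9-fold higher number (0.29 log units; within the scatter) from compound 3 to compound 4, 1.1-fold (0.04 log units) apart, within the scatter of two such steps. The exchange of the amine at the chain end, now also read with the 4-nitrophenyl group in place, gives a 1.2-fold lower number from compound 2 to compound 4 (0.06 log units; within the scatter), and the two amines again cannot be told apart: the same change on two cores in this assay, a 1.1-fold lower number (0.02 log units; within the scatter) from compound 1 to compound 3 and a 1.2-fold lower number (0.06 log units; within the scatter) from compound 2 to compound 4, 1.1-fold (0.04 log units) apart, within the scatter of two such steps. The compounds shown leave open what an amino or methoxy group at the same ring carbon would do, and how a morpholine at the chain end would compare.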